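A few compounds are considered here, and "the series" means these few. Any claim that something is new, unique, unknown or untested is made for them only; others in the source may bear on it.

Measured in a functional assay on cells (T-cell line, Homo sapiens) for inhibition; a lower number here means a stronger inhibitor, a higher number a weaker inhibitor:
- compound 1 `COc1ccc(CCCN2CCC(CNC(c3ccccc3)c3ccccc3)CC2)cc1`: 2800 nM
- compound 2 `COc1ccc(CCCN2CCC(COCc3ccccc3)CC2)cc1`: 2100 nM
- compound 3 `CN1CCC(COC(c2ccccc2)c2ccccc2)CC1`: > 20000 nM

Compound 3 stands at > 20000 nM, which is a limit of this assay and not a number.

Compound 1 at 2800 nM and compound 2 at 2100 nM both give numbers, and these two values lie within the scatter of each other.

Compound 4 `COc1ccccc1CCCN1CCC(COC(c2ccccc2)c2ccccc2)CC1` is compound 3 with 2-(2-methoxyphenyl)ethyl in place of hydrogen on a saturated chain carbon bound to an amine nitrogen in a ring. The counted difference is 2-(2-methoxyphenyl)ethyl in place of hydrogen on a saturated chain carbon bound to an amine nitrogen in a ring.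

Within the data shown here, no measured pair shows this change, so the expected size of the step rests on indirect evidence only. Compound 1 at 2800 nM and compound 2 at 2100 nM each carry a methoxyphenyl ring on a chain from the ring amine nitrogen, as compound 4 will. On that basis, a step towards stronger inhibition, well beyond the scatter, is expected in this assay, with compound 4 reaching a measurable number near those two values.

The expected step is an at least 10-fold lower number from compound 3 to compound 4 (1.00 log units; beyond the scatter).

For compound 4 the estimated value is 2000 nM, with an expected range of 600 nM to 7000 nM.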

Compound 4, half-maximal inhibitory concentration: 2400 nM
For compound 4 the middle estimate is 1.2-fold (0.08 log units) below the measured one, within the range that was stated.
By their numbers in this assay, from the lowest: compounds 2, 4 and 1 (each within the scatter of the next). At a limit, above all of these: compound 3.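

In this assay, among these compounds, 2-(2-methoxyphenyl)ethyl in place of hydrogen on a saturated chain carbon bound to an amine nitrogen in a ring gives the first step at this position, an at least 8.3-fold lower number from compound 3 to compound 4 (0.92 log units; beyond the scatter), and compound 4 gives a measurable 2400 nM. Compound 3 stands at > 20000 nM, which is a limit of this assay and not a number. The step is therefore a lower bound on the change and its full size stays unknown, because one end of the pair sits at that limit: the limit of > 20000 nM in this assay, at which 1 of the 4 values shown sits.

This single pair cannot tell how much of the step belongs to the aromatic ring, the chain or the methoxy group, since all three enter together. Open questions are whether plain 2-phenylethyl, without the methoxy group, or a longer chain ending in a carboxylic acid at the same place would give a similar number, and whether an amine in place of the methoxy group would keep the number of compound 4.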